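This account rests on a few compounds, and the source may have more. Where it says the series, first, only, none or still open, it means among the compounds named here.

Measured in a functional assay on HL-60 cells (Homo sapiens) for cytotoxicity, read by MTT assay, with a stated time of 72 h; a higher number here means a weaker inhibitor, a lower number a stronger inhibitor:
- Compound 1 `O=C(COc1ccccc1)Nc1nnc(-c2cccc(O)c2O)s1`: 11200 nM
- Compound 2 `CC(=O)Nc1nnc(-c2cccc(O)c2O)s1`: 49000 nM

Of these two, compound 2 has the higher number, 49000 nM, which makes it the weaker inhibitor. Compound 3 `Cc1ccc(C(=O)Nc2nnc(-c3cccc(O)c3O)s2)cc1` differs from compound 2 in one place: 4-methylphenyl in place of methyl on a carbonyl carbon, with 4-methylphenyl in place of methyl on a carbonyl carbon. Among the measured compounds shown here, one measured step bears on this: a 4.4-fold higher number from compound 1 to compound 2 (0.64 log units; beyond the scatter), with hydrogen in place of phenoxy. That step was modest but beyond the scatter. Read in reverse, it points to a modest fall in the number when the small group gives way to a larger one, though a single step is thin evidence. The expected change is a 3.8-fold lower number from compound 2 to compound 3 (0.58 log units; beyond the scatter). For compound 3 the estimated value is 13000 nM, with an expected range of 4000 nM to 42000 nM.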

Compound 3, half-maximal inhibitory concentration: 10600 nM
Beside the measured number, compound 3's estimate is 1.2-fold (0.09 log units) above it; the measured number falls inside the stated range.
By their numbers in this assay, from the lowest: compounds 3 and 1 (each within the scatter of the next); then compound 2.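

On the carbonyl carbon, 4-methylphenyl in place of methyl lowers the number (a 4.6-fold lower number from compound 2 to compound 3 (0.66 log units; beyond the scatter)), so a second, different large group also improves on methyl. Exchanging phenoxymethyl for 4-methylphenyl makes no difference that can be read (a 1.1-fold lower number from compound 1 to compound 3 (0.02 log units; within the scatter)), so these two groups cannot be told apart here. No supporting measurement explains these results. Open, as far as these compounds go, is whether an amine, a carboxylic acid or a longer chain on this carbonyl carbon would move the number further. Also open, from the compounds shown here alone, is whether plain phenyl, without the methyl, would match 4-methylphenyl.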